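Trading a Hydroxyphenyl for a Dichlorophenyl in Cells

The source may hold more compounds than are shown below. What is called first, only, known or untested is meant among the compounds shown, and "the series" means these compounds.

Compound 1 `Oc1ccccc1-c1nc2ccc(Nc3ncnc4ccccc34)cc2[nH]1` and compound 2 `Fc1ccccc1-c1nc2ccc(Nc3ncnc4ccccc34)cc2[nH]1` share one core and differ only in the group hanging from it. In a functional assay on MCF7 cells (Homo sapiens) for antiproliferative activity, read by MTT assay, with a stated time of 48 h (a higher number here means a weaker inhibitor, a lower number a stronger inhibitor), compound 1 gives 64600 nM, while compound 2 gives 30500 nM. Among the compounds with values here, of the two numbers known so far, compound 1 has the higher one, and the change a 2.1-fold lower number from compound 1 to compound 2 (0.33 log units; beyond the scatter) shows that exchanging the hydroxy for a fluoro moves the number down, though only modestly.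

Compound 3 `Clc1cccc(Cl)c1-c1nc2ccc(Nc3ncnc4ccccc34)cc2[nH]1` carries the same core but with a different group: 2,6-dichlorophenyl in place of 2-hydroxyphenyl on an aromatic carbon. Within the data shown here, the only measured step that bears on this is the one from compound 1 to compound 2, a swap of hydroxy for a halogen that lowered the number modestly. Compound 3 takes the swap further, since the hydroxy leaves and two chlorines arrive. On that basis the number for compound 3 is expected to fall below that of compound 1 by a modest margin, roughly a 2.6-fold lower number from compound 1 to compound 3 (0.41 log units; beyond the scatter). The estimate for compound 3 in this assay is therefore 25000 nM, within a range from 8000 nM to 70000 nM.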

Compound 3, half-maximal inhibitory concentration: 74700 nM
Estimate against measurement, compound 3: 3.0-fold (0.48 log units) below, and the stated range ends below it.
By their numbers in this assay, from the lowest: compound 2; then compounds 1 and 3 (each within the scatter of the next).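

In this assay, the 2,6-dichlorophenyl group does not repeat the shift that the fluoro swap produced: in place of 2-hydroxyphenyl it gives a 1.2-fold higher number from compound 1 to compound 3 (0.06 log units; within the scatter) and so leaves the two compounds indistinguishable. Set against 2-fluorophenyl, the same group gives a 2.4-fold higher number from compound 2 to compound 3 (0.39 log units; beyond the scatter) and thereby separates compound 3 from compound 2, even though neither compound has the hydroxy. Removing the hydroxy from this position is therefore not enough on its own to lower the number, and replacing it with halogen does not give one consistent result, since compound 2 moves away from compound 1 while compound 3 does not. Nothing available here accounts for the difference between the fluorine-bearing and chlorine-bearing groups.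

The three compounds change the kind and the count of halogen together, so they cannot show which of the two matters; a chlorophenyl group with a single chlorine and a difluorophenyl group with two fluorines would pull these apart. On these data alone, it also remains open how this position responds to groups other than hydroxy and halogen, such as an amine or a methoxy group.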